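The source may report more compounds than this note shows. Statements on the series, on what has been measured and on what is new or still open speak of the compounds shown alone.

Measured compounds in a functional assay on Bel-7402 cells (Homo sapiens) for cytotoxicity, read by MTT assay, with a stated time of 48 h; a higher number here means a weaker inhibitor, a lower number a stronger inhibitor:
- compound 1 `CCn1cc(-c2nc3ccccc3[nH]2)c(=O)c2cc(F)c(N3CCNCC3)nc21`: 4100 nM
- compound 2 `CCn1cc(-c2nc3ccccc3o2)c(=O)c2cc(F)c(Cl)cc21`: 28900 nM
- compound 3 `CCn1cc(-c2nc3ccccc3o2)c(=O)c2cc(F)c(N3CCN(C)CC3)cc21`: 2000 nM

Compound 3 holds the lowest of the three numbers in this assay. Going by the values given here, its nearest neighbour is compound 1, whose number is higher by a gap beyond the scatter; its furthest is compound 2, the step of a 14-fold lower number from compound 2 to compound 3 (1.16 log units; beyond the scatter) being the only single-point change among the measured compounds. That step concerns the substituent on the six-membered ring of the core and says nothing about the bicyclic ring at the other position.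

Compound 4 `CCn1cc(-c2nc3ccccc3s2)c(=O)c2cc(F)c(N3CCN(C)CC3)cc21` is the next member. It differs from compound 3 in one place: 1,3-benzothiazol-2-yl in place of 1,3-benzoxazol-2-yl on an aromatic carbon. Among the compounds with values here, no measured step bears on this exchange. Compound 1 carries a different ring at the same place, but it also differs from compound 3 elsewhere in the core and in the piperazine substituent, so its value cannot be separated into a contribution from that ring alone. With nothing to pull the number in either direction, the expected step of no change at the digits printed from compound 3 to compound 4 (within the scatter) is none beyond the scatter. Compound 4 is therefore estimated at 2000 nM in this assay, with a range of 700 nM to 6000 nM.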

Compound 4, half-maximal inhibitory concentration: 24000 nM
Beside the measured number, compound 4's estimate is 12-fold (1.08 log units) below it; the measured number lies above the stated range.
By their numbers in this assay, from the lowest: compound 3; then compound 1; then compounds 4 and 2 (each within the scatter of the next).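

In this assay, the exchange of 1,3-benzoxazol-2-yl for 1,3-benzothiazol-2-yl on the shared core gives a 12-fold higher number from compound 3 to compound 4 (1.08 log units; beyond the scatter) and so shows that this place on the aromatic carbon is not indifferent to the bicyclic group it carries. The two groups match in heavy-atom count, ring types, hydrogen-bond donors and acceptors, and differ in composition only by oxygen against sulfur, so a large step here follows from a single-atom exchange within the group. Going by these compounds alone, until now the only readable step was a 14-fold lower number from compound 2 to compound 3 (1.16 log units; beyond the scatter) at the chloro place, and the series now has a large step at each of two places, one toward a lower number and one toward a higher number. No measurement at hand explains the step from oxygen to sulfur.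

Whether the step holds with chloro in place of the 4-methylpiperazin-1-yl group remains open, as the compounds shown give no such pair. Also open, from the compounds shown here alone, is how a plain phenyl ring, a pyridin-2-yl ring or a carboxylic acid at this place would compare with 1,3-benzoxazol-2-yl on the same core.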